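The source may report more compounds than this note shows. Statements on the series, on what has been measured and on what is new or still open speak of the compounds shown alone.

Compound 1 `N#Cc1cccc(-c2cnc(C(=O)CCc3ccc(-c4ccccc4)cc3)o2)n1` gives 2.9 nM in an assay for inhibition of Fatty-acid amide hydrolase 1 (Rattus norvegicus); a higher number here means a weaker inhibitor, a lower number a stronger inhibitor. Among the compounds with values here, compound 2 `NC(=O)c1ccc(-c2cnc(C(=O)CCc3ccc(-c4ccccc4)cc3)o2)nc1` gives 1.3 nM in this assay, the lowest of the two numbers measured; the only step measured so far, a 2.2-fold lower number from compound 1 to compound 2 (0.35 log units; beyond the scatter), is modest yet beyond the scatter. Compound 3 `O=C(O)c1ccc(-c2cnc(C(=O)CCc3ccc(-c4ccccc4)cc3)o2)nc1` differs from compound 2 by hydroxy in place of amino on a carbonyl carbon, carbamoyl to carboxy. Within the data shown here, no measured step exchanges these two groups, and the step of a 2.2-fold lower number from compound 1 to compound 2 (0.35 log units; beyond the scatter) alters a different group, so it does not bear on this change. For compound 3 a small rise is expected, a 3.8-fold higher number from compound 2 to compound 3 (0.59 log units; beyond the scatter). Compound 3 is therefore estimated at 5 nM, between 1.5 nM and 20 nM.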

Compound 3, inhibition constant: 14 nM
For compound 3 the middle estimate is 2.8-fold (0.45 log units) below the measured one, and the stated range covers the measured number.
By their numbers in this assay, from the lowest: compound 2; then compound 1; then compound 3.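

In this assay the carbonyl carbon proves sensitive to the group it carries: hydroxy in place of amino gives an 11-fold higher number from compound 2 to compound 3 (1.03 log units; beyond the scatter), a large step for one exchanged heavy atom. The modest step of a 4.8-fold higher number from compound 1 to compound 3 (0.68 log units; beyond the scatter) also places 5-carboxypyridin-2-yl above 6-cyanopyridin-2-yl, so the lower number seen with 5-carbamoylpyridin-2-yl does not carry over to the carboxy group. No measured evidence accounts for this rise. Open, going by these compounds, is whether a methyl ester or a methylamide on the same carbonyl carbon would stay near compound 2 or near compound 3 in this assay.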